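Methoxy to butoxy on compound 2

This account rests on a few compounds, and the source may have more. Where it says the series, first, only, none or still open, it means among the compounds named here.

Of the compounds shown here, two have numbers so far. In a functional assay on MCF7 cells (Homo sapiens) for cytotoxicity, read by MTT assay (on this read-out lower numbers stand for stronger inhibition and higher numbers for weaker inhibition), compound 1 (`CCCCOc1c(Br)cc(/C=C2\CCC/C(=C\c3cccc([N+](=O)[O-])c3)C2=O)cc1OC`) gives 5.97 ug/mL and compound 2 (`COc1cc(/C=C2\CCC/C(=C\c3ccc([N+](=O)[O-])cc3)C2=O)cc(Br)c1OC`) gives 11 ug/mL on the same read-out, so the two values lie within the scatter of each other. Compound 2 therefore cannot be set apart from compound 1 on these numbers. The two structures differ in more than one place, and no single change can be read from this pair.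

Compound 3 (`CCCCOc1c(Br)cc(/C=C2\CCC/C(=C\c3ccc([N+](=O)[O-])cc3)C2=O)cc1OC`) keeps compound 2 unchanged except for propyl in place of hydrogen on a saturated chain carbon bound to an oxygen on an aromatic ring, which reads as methoxy to butoxy. Among the compounds with values here, the only guide is compound 1, which also carries butoxy and gives 5.97 ug/mL in this assay without a matched partner. In this assay the expected outcome is a 1.5-fold lower number from compound 2 to compound 3 (0.17 log units; within the scatter) as a modest estimated move toward lower numbers, with no clear exit from the scatter. Compound 3 is estimated at 7.5 ug/mL with an expected range from 3 ug/mL to 16 ug/mL on this read-out.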

Compound 3, half-maximal inhibitory concentration: 27 ug/mL
Compound 3: the middle estimate sits 3.6-fold (0.56 log units) below what was measured; measured number outside the range, above it.
By their numbers in this assay, from the lowest: compounds 1 and 2 (each within the scatter of the next); then compound 3.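

In this assay, methoxy to butoxy now has a matched reading in the presence of 4-nitrophenyl: a 2.5-fold higher number from compound 2 to compound 3 (0.39 log units; beyond the scatter), a move toward weaker inhibition that the unmatched compound 1 could not reveal. With butoxy held fixed, 4-nitrophenyl in place of 3-nitrophenyl gives a 4.5-fold higher number from compound 1 to compound 3 (0.66 log units; beyond the scatter), so carrying butoxy does not by itself set the level of the number, and the result at this position has to be read together with the nitrophenyl group on the double-bonded chain carbon. No measurement at hand explains either step.

Whether methoxy to butoxy gives a step of the same direction with 3-nitrophenyl stays open, as compound 1 has no matched methoxy partner among the compounds shown. Also open, going by these compounds, is how the series would read with an ethoxy group, a longer chain such as hexyloxy, or a butoxy chain ending in an amine at this place, and so whether the step from methoxy to butoxy continues along a chain series or belongs to butoxy alone.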